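Chlorine to bromine swap on the benzyl group of compound 3

The source may report more compounds than this note shows. Statements on the series, on what has been measured and on what is new or still open speak of the compounds shown alone.

Measured so far in a functional assay on SW480 cells (Homo sapiens) for cytotoxicity, read by MTT assay, with a stated time of 48 h; on this read-out higher numbers stand for weaker inhibition and lower numbers for stronger inhibition:
- compound 1, `N#Cc1ccc(Cn2cc(COc3ccc4c(=O)ccoc4c3)nn2)cc1`: > 100000 nM
- compound 2, `O=c1ccoc2cc(OCc3cn(Cc4ccccc4)nn3)ccc12`: 42900 nM
- compound 3, `O=c1ccoc2cc(OCc3cn(Cc4cccc(Cl)c4)nn3)ccc12`: 12900 nM

Compound 1 `N#Cc1ccc(Cn2cc(COc3ccc4c(=O)ccoc4c3)nn2)cc1` gives only a limit of this assay, > 100000 nM (the limit of > 100000 nM in this assay, at which 1 of the 3 values shown sits). Compound 2 `O=c1ccoc2cc(OCc3cn(Cc4ccccc4)nn3)ccc12` gives 42900 nM in this assay. Compound 3 `O=c1ccoc2cc(OCc3cn(Cc4cccc(Cl)c4)nn3)ccc12` gives 12900 nM in this assay, the lowest of the two numbers measured. The step of a 3.3-fold lower number from compound 2 to compound 3 (0.52 log units; beyond the scatter) shows that a halogen on the benzyl ring lowers the number; the step of an at least 2.3-fold lower number from compound 1 to compound 2 (0.36 log units; beyond the scatter) and the step of an at least 7.7-fold lower number from compound 1 to compound 3 (0.88 log units; beyond the scatter) start from a limit and give only a floor to their size.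

Compound 4 `O=c1ccoc2cc(OCc3cn(Cc4ccc(Br)cc4)nn3)ccc12` is not yet measured in this assay. It differs from compound 3 by 4-bromophenyl in place of 3-chlorophenyl on a saturated chain carbon bound to an aromatic nitrogen. Within the data shown here, no measured step compares one halogen with another or one ring position with another, so the step of a 3.3-fold lower number from compound 2 to compound 3 (0.52 log units; beyond the scatter) is the nearest guide, and it concerns a halogen against hydrogen rather than bromine against chlorine. A halogen is kept in compound 4, so a number close to that of compound 3 is expected, with the step of a 1.2-fold lower number from compound 3 to compound 4 (0.07 log units; within the scatter) expected to stay within the scatter. For compound 4 the estimate in this assay is 11000 nM, between 4000 nM and 32000 nM.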

Compound 4, half-maximal inhibitory concentration: 37500 nM
Compound 4: the middle estimate sits 3.4-fold (0.53 log units) below what was measured; the whole stated range lies below it.
By their numbers in this assay, from the lowest: compound 3; then compounds 4 and 2 (each within the scatter of the next). At a limit, above all of these: compound 1.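

In this assay, the change from 3-chlorobenzyl to 4-bromobenzyl gives a 2.9-fold higher number from compound 3 to compound 4 (0.46 log units; beyond the scatter), so keeping a halogen on the benzyl ring does not by itself hold the number of compound 3. Bromo in place of hydrogen gives a 1.1-fold lower number from compound 2 to compound 4 (0.06 log units; within the scatter), so the lowering seen with compound 3 does not extend to all the halogenated compounds here, and compound 4 goes against it. The step of an at least 2.6-fold lower number from compound 1 to compound 4 (0.42 log units; beyond the scatter) is only a floor, set by a limit for compound 1: the limit of > 100000 nM in this assay, at which 1 of the 4 values shown sits.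

The step from compound 3 to compound 4 changes both the halogen and its ring position, and the compounds shown do not separate the two; a 4-chlorophenyl or a 3-bromophenyl group would. From the compounds shown here alone, how a benzyl ring carrying a methoxy group or a carboxylic acid reads also remains open.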